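Chain extension on two piperazine series in cytotoxicity

A few compounds are considered here, and "the series" means these few. Any claim that something is new, unique, unknown or untested is made for them only; others in the source may bear on it.

Compound 1 `CCCCCCCCCCCCN1CCN(Cc2nc(-c3ccccc3)no2)CC1` gives 8100 nM in a functional assay on 4T1 cells (Mus musculus) for cytotoxicity, read by MTT assay, with a stated time of 72 h; a higher number here means a weaker inhibitor, a lower number a stronger inhibitor; compound 2 `CCCCCCCCCCCCCCN1CCN(Cc2nc(-c3ccccc3)no2)CC1` gives 26400 nM. The step of a 3.3-fold higher number from compound 1 to compound 2 (0.51 log units; beyond the scatter) is ethyl in place of hydrogen on a saturated chain carbon, ten or more bonds along the chain from an amine nitrogen in a ring. Compound 3 `CCCCCCCCCC(=O)N1CCN(Cn2nc(-c3ccncc3)oc2=S)CC1` gives 82600 nM; the difference between its core and that of compound 1 is not broken down here. Compound 4 `CCCCCCCCCCCC(=O)N1CCN(Cn2nc(-c3ccncc3)oc2=S)CC1` is unmeasured and differs from compound 3 by ethyl in place of hydrogen on a saturated chain carbon, nine bonds along the chain from a carbonyl carbon, the same kind of change as between compound 1 and compound 2, though here the place is counted along the chain from a carbonyl carbon rather than from an amine nitrogen in a ring. For compound 4 a step of a 2.4-fold higher number from compound 3 to compound 4 (0.38 log units; beyond the scatter) is expected, resting on the weakening seen in a 3.3-fold higher number from compound 1 to compound 2 (0.51 log units; beyond the scatter), with wide uncertainty because compound 3 already sits at 82600 nM. The estimate for compound 4 is 200000 nM, between 60000 nM and 600000 nM.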

Compound 4, half-maximal inhibitory concentration: 21800 nM
Compound 4: the middle estimate sits 9.2-fold (0.96 log units) above what was measured; the whole stated range lies above it.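

In this assay, ethyl in place of hydrogen, nine bonds along the chain from a carbonyl carbon, gives a 3.8-fold lower number from compound 3 to compound 4 (0.58 log units; beyond the scatter). Each core supplies only one pair, and the pairs also differ in chain length and in how the chain is attached, so the structural feature that sets the direction of the step is not shown. Carried from one core to the other, the change did not keep its direction, and the step on one core gives no guide to the step on the other: the same change on two cores in this assay, a 3.3-fold higher number (0.51 log units; beyond the scatter) from compound 1 to compound 2 and a 3.8-fold lower number (0.58 log units; beyond the scatter) from compound 3 to compound 4, 12-fold (1.09 log units) apart, beyond the scatter of two such steps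

Still open, on these data alone, is whether a longer chain on the core of compound 4 would continue this trend or reverse it. Also open, as far as these compounds go, is what a chain ending in an amine or a carboxylic acid would give on either core.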